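The compounds below may be only part of what the source reports. "The series", "measured", "known", "first", "only" and "open" are said of these compounds alone.

Compound 1 `Cc1cc(=O)oc2nn(C)c(C)c12` in a functional assay on the whole organism with Mus musculus as the target, in the writhing test (on this read-out lower numbers stand for an effect already at smaller amounts and higher numbers for an effect only at larger amounts of compound), gives 6.09 mg/kg. Compound 2 `CCCCn1nc2oc(=O)cc(C)c2c1C` in this assay is reported only as a limit, > 100 mg/kg; this is the limit of > 100 mg/kg in this assay, at which 1 of the 3 values shown sits. The change between them, (propyl in place of hydrogen on a saturated chain carbon bound to an aromatic nitrogen), gives an at least 16-fold higher number from compound 1 to compound 2 (1.21 log units; beyond the scatter). Compound 3 `Cc1cc(=O)oc2c1c(C)nn2C` has the same atoms as compound 1 joined differently; the difference between the two cores is not broken down here. Compound 3 in this assay gives 11.6 mg/kg, and against compound 1 this sits within the scatter. Compound 4 `CCCCn1nc(C)c2c(C)cc(=O)oc21` carries the same change relative to compound 3, (propyl in place of hydrogen on a saturated chain carbon bound to an aromatic nitrogen), at the same place. For compound 4 the step is expected to be a 13-fold higher number from compound 3 to compound 4 (1.11 log units; beyond the scatter), resting on compound 1 to compound 2 with an at least 16-fold higher number from compound 1 to compound 2 (1.21 log units; beyond the scatter). Compound 4 is accordingly estimated at 150 mg/kg, most likely returned as a limit rather than a number.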

Compound 4, dose for half-maximal effect: > 100 mg/kg
Compound 4 gave a limit, no number (the forecaster's own chance of this, stated with the estimate: 65%); the middle value does not contradict the limit.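

In this assay the change from hydrogen to propyl on a saturated chain carbon bound to an aromatic nitrogen, carried to the second core, gives an at least 8.6-fold higher number from compound 3 to compound 4 (0.93 log units; beyond the scatter) and again lies beyond the scatter. Compound 4 stands at > 100 mg/kg as a limit and not a number. The direction of the step therefore carries from one core to the other, but its size cannot be compared: the same change on two cores in this assay, an at least 16-fold higher number (1.21 log units; beyond the scatter) from compound 1 to compound 2 and an at least 8.6-fold higher number (0.93 log units; beyond the scatter) from compound 3 to compound 4; the limit leaves it open whether they differ

Where between methyl and butyl the number climbs stays open on both cores, as no ethyl or propyl chain on the aromatic nitrogen is among the compounds shown. In this assay, on these data alone, it also stays open how a butyl chain carrying an amine or a carboxylic acid would read.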